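Methoxy-to-Fluoro Swap Repeated on the Propyl Core

The compounds below may be only part of what the source reports. "The series", "measured", "known", "first", "only" and "open" are said of these compounds alone.

Compound 1 `COc1cccc(OS(=O)(=O)c2ccc(N3CCN(C)C3=O)cc2)c1` gives 3000 nM in a functional assay on MCF7 cells (Homo sapiens) for antiproliferative activity, read by sulforhodamine B assay, with a stated time of 48 h; a lower number here means a stronger inhibitor, a higher number a weaker inhibitor.
Compound 3 `CCCN1CCN(c2ccc(S(=O)(=O)Oc3cccc(OC)c3)cc2)C1=O` gives 6300 nM in this assay.
Compound 2 `CN1CCN(c2ccc(S(=O)(=O)Oc3cccc(F)c3)cc2)C1=O` reaches only the limit > 100000 nM in this assay, so no number is known for it.

The change from compound 1 to compound 2 is fluoro in place of methoxy on an aromatic carbon, and it produced an at least 33-fold higher number from compound 1 to compound 2 (1.52 log units; beyond the scatter), a value sitting at the limit (the limit of > 100000 nM in this assay, at which 1 of the 3 values shown sits). The two cores differ by ethyl in place of hydrogen on a saturated chain carbon bound to an amide-type nitrogen in a ring, which gave a 2.1-fold higher number from compound 1 to compound 3 (0.32 log units; beyond the scatter). Compound 4 `CCCN1CCN(c2ccc(S(=O)(=O)Oc3cccc(F)c3)cc2)C1=O` has not yet been measured; it differs from compound 3 by fluoro in place of methoxy on an aromatic carbon, the same change at the same place as before. Starting from the weaker compound 3, the step is expected to be a 32-fold higher number from compound 3 to compound 4 (1.50 log units; beyond the scatter), resting on the large loss seen in an at least 33-fold higher number from compound 1 to compound 2 (1.52 log units; beyond the scatter). Compound 4 is therefore estimated at 200000 nM, most likely reported only as a limit.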

Compound 4, half-maximal inhibitory concentration: 24000 nM
Compound 4: middle estimate off by 8.3-fold (0.92 log units), on the high side; the whole stated range lies above it.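

Replacing methoxy with fluoro weakens activity on both cores, but the size of the loss does not carry over, as the step on the core of compound 3 is a 3.8-fold higher number from compound 3 to compound 4 (0.58 log units; beyond the scatter), and the two steps differ: the same change on two cores in this assay, an at least 33-fold higher number (1.52 log units; beyond the scatter) from compound 1 to compound 2 and a 3.8-fold higher number (0.58 log units; beyond the scatter) from compound 3 to compound 4, at least 8.7-fold (0.94 log units) apart, beyond the scatter of two such steps

With fluoro on the ring, the chain change gives an at least 4.1-fold lower number from compound 2 to compound 4 (0.61 log units; beyond the scatter), the opposite direction from the methoxy pair: the same change on two cores in this assay, a 2.1-fold higher number (0.32 log units; beyond the scatter) from compound 1 to compound 3 and an at least 4.1-fold lower number (0.61 log units; beyond the scatter) from compound 2 to compound 4, at least 8.7-fold (0.94 log units) apart, beyond the scatter of two such steps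

Compound 2 gives only a limit, > 100000 nM, and these compounds do not show why the swap costs less on the core of compound 3.

On these data alone, a butyl chain in place of propyl remains open, as does whether chloro or hydroxy on the aromatic ring would follow fluoro or methoxy.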